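The source may hold more compounds than are shown below. What is called first, only, known or untested is meant among the compounds shown, and "the series" means these compounds.

Measured in an assay on membranes from brain for displacement of a labelled ligand from adenosine receptor A1 (Rattus norvegicus), read by scintillation counting, with a stated time of 90 min; a higher number here means a weaker inhibitor, a lower number a stronger inhibitor: compound 1 `COc1cccc(CCCC(=O)Nc2nc3ccccc3c(=O)s2)c1` gives 22.5 nM; compound 2 `O=C(CCc1ccccc1)Nc1nc2ccccc2c(=O)s1` gives 422 nM. Compound 3 `O=C(CCc1ccccc1F)Nc1nc2ccccc2c(=O)s1` gives > 10000 nM, which is a limit of this assay and not a number.

Compound 3 thus stands at the weak end of the three values shown. Among the measured compounds shown here, the one step reaching it, an at least 23-fold higher number from compound 2 to compound 3 (1.37 log units; beyond the scatter), fluoro in place of hydrogen on an aromatic carbon, ends at the limit of > 10000 nM in this assay, at which 1 of the 3 values shown sits. Compound 4 `O=C(CCc1ccccc1Br)Nc1nc2ccccc2c(=O)s1` differs from compound 3 by bromo in place of fluoro on an aromatic carbon. For the measured compounds named here, no measured step involves bromo; the only step that bears on compound 4 is the large one just named, and nothing in the measured values points to a recovery from where compound 3 stands. Compound 4 is therefore expected to give a step of a number no higher from compound 3 to compound 4 (the limit leaves the size open), none beyond the scatter. For compound 4 the estimate in this assay is 10000 nM, range 3000 nM to 40000 nM, most likely reported again only as a limit.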

Compound 4, inhibition constant: > 10000 nM
Compound 4 ended at the assay's limit; the forecaster's own chance of this, stated with the estimate: 60%; the middle value lies on the limit itself.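

In this assay, bromo in place of hydrogen gives an at least 23-fold higher number from compound 2 to compound 4 (1.37 log units; beyond the scatter). The loss from compound 2 is therefore not particular to fluoro: 2-fluorophenyl and 2-bromophenyl both produce it at this position. Compound 3 and compound 4 both stand at a limit, so the step between them cannot be read and no order of the two halogens follows: the limit of > 10000 nM in this assay, at which 2 of the 4 values shown sit.

Open, as far as these compounds go, is whether any other group at this place, such as a methyl, a hydroxyl or an amine, keeps the value of compound 2. Also open, from the compounds shown here alone, is whether fluoro or bromo elsewhere on the aromatic ring brings the same loss.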